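Working notes: trifluoromethoxy for fluoro, compound 3 to compound 4

The source may report more compounds than this note shows. Statements on the series, on what has been measured and on what is new or still open speak of the compounds shown alone.

In an ADME assay on cells (Hepatocyte, Rattus norvegicus) for metabolic stability (a higher number here means faster removal of the compound, a lower number slower removal), compound 3 `O=C(O)COC(=O)N(C1CC1)[C@H]1c2ccccc2N(C(=O)c2ccc(F)cc2)[C@H]2CC[C@H]21` gives 13 uL/min, level with compound 1 `O=C(O)CCC(=O)N(C1CC1)[C@H]1c2ccccc2N(C(=O)c2ccc(OC(F)(F)F)cc2)[C@H]2CC[C@H]21` at 13 uL/min, the two together the lowest of the three numbers. Among the measured compounds shown here, compound 2 `O=C(O)COC(=O)N(C1CC1)[C@H]1c2ccccc2N(C(=O)c2cccc(F)c2)[C@H]2CC[C@H]21` gives 20 uL/min; the only measured step, a 1.5-fold lower number from compound 2 to compound 3 (0.19 log units; within the scatter), lies within the scatter. Compound 4 `O=C(O)COC(=O)N(C1CC1)[C@H]1c2ccccc2N(C(=O)c2ccc(OC(F)(F)F)cc2)[C@H]2CC[C@H]21` differs from compound 3 by trifluoromethoxy in place of fluoro on an aromatic carbon. For the measured compounds named here, no measured step isolates this change. Compound 1 carries the same trifluoromethoxy group on a different acid chain, and its number sits level with compound 3, so nothing in the series points to movement. The expected step in this assay is therefore a 1.1-fold higher number from compound 3 to compound 4 (0.03 log units; within the scatter), none beyond the scatter. Compound 4 is expected to give 14 uL/min, with a range from 7 uL/min to 28 uL/min.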

Compound 4, intrinsic clearance in a liver preparation (reported as CLH), per the amount of preparation that the assay uses: 18 uL/min
Compound 4: middle estimate off by 1.3-fold (0.11 log units), on the low side, within the range that was stated.
By their numbers in this assay, from the lowest: compounds 1, 3, 4 and 2 (each within the scatter of the next).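

Trifluoromethoxy in place of fluoro now has a direct reading in this assay: the step is a 1.4-fold higher number from compound 3 to compound 4 (0.14 log units; within the scatter) and so shows no readable shift at this aromatic carbon. The step is a 1.1-fold lower number from compound 2 to compound 4 (0.05 log units; within the scatter) for the change from 3-fluorophenyl, and a 1.4-fold higher number from compound 1 to compound 4 (0.14 log units; within the scatter) for carboxymethoxy in place of 2-carboxyethyl, so neither change separates these compounds either. Nothing available explains why these numbers stay together. Still open, on these data alone, is whether an amine or a nitrile on this aromatic carbon would move the number beyond the scatter, and whether a longer chain in place of carboxymethoxy would do so.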